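The source may hold more compounds than are shown below. What is called first, only, known or untested is meant among the compounds shown, and "the series" means these compounds.

Compound 1 `C/C(=N\NC(=O)/C(C#N)=C/c1ccc(O)cc1)c1c(O)c2ccc(O)cc2oc1=O`: 61300 nM
Compound 2 `COc1ccc(/C=C(\C#N)C(=O)N/N=C(\C)c2c(O)c3ccc(O)cc3oc2=O)cc1`: 96100 nM

Both values come from a functional assay on NRK-49F cells (Rattus norvegicus) for cytotoxicity, read by MTT assay, with a stated time of 24 h; on this read-out lower numbers stand for stronger inhibition and higher numbers for weaker inhibition. Among the compounds with values here, these are the only two numbers so far, and compound 2, with 96100 nM, lies within the scatter of compound 1, so the two cannot be ranked.

The next compound, compound 3 `C/C(=N\NC(=O)/C(C#N)=C/c1ccc(N(C)C)cc1)c1c(O)c2ccc(O)cc2oc1=O`, keeps everything else in compound 2 and carries dimethylamino in place of methoxy on an aromatic carbon.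

Within the data shown here, only one measured step bears on this change: a 1.6-fold higher number from compound 1 to compound 2 (0.20 log units; within the scatter). There, methyl takes the place of hydrogen on an oxygen on an aromatic ring, and the result stays within the scatter. Among the measured compounds shown here, this is a different exchange, and no measured compound carries dimethylamino, so the guidance is indirect. With that small step as the only reference, no shift beyond the scatter is expected in this assay, and no direction can be argued.

The expected step is a 1.3-fold lower number from compound 2 to compound 3 (0.11 log units; within the scatter). For compound 3 the estimated value is 75000 nM, with an expected range from 35000 nM to 160000 nM.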

Compound 3, half-maximal inhibitory concentration: 53400 nM
Compound 3: middle estimate off by 1.4-fold (0.15 log units), on the high side, within the range that was stated.
By their numbers in this assay, from the lowest: compounds 3, 1 and 2 (each within the scatter of the next).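

In this assay, the position para to a large group now carries three different groups, and the exchange of methoxy for dimethylamino gives a 1.8-fold lower number from compound 2 to compound 3 (0.26 log units; within the scatter). Dimethylamino in place of hydroxy gives a 1.1-fold lower number from compound 1 to compound 3 (0.06 log units; within the scatter), so a nitrogen-bearing group at this position cannot be told apart from either oxygen-bearing group on this read-out, and hydroxy, methoxy and dimethylamino cannot be ranked. Nothing measured here offers an explanation of this result.

The compounds shown leave open whether a carboxylic acid, a primary amine or a longer alkoxy chain at this position would move the number beyond the scatter. They also leave open whether changes elsewhere on the shared core would do so, as every difference shown lies at this one position.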